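This account rests on a few compounds, and the source may have more. Where it says the series, first, only, none or still open, it means among the compounds named here.

Measured compounds in a functional assay on NCI-H226 cells (Homo sapiens) for inhibition, read by sulforhodamine B assay, with a stated time of 48 h; on this read-out higher numbers stand for weaker inhibition of growth and lower numbers for stronger inhibition of growth:
compound 1 `COc1cc(-c2nn(-c3cccc(NC(=O)Nc4cc(C(F)(F)F)cc(C(F)(F)F)c4)c3)cc2-c2ccncc2)ccc1Cl`, 21800 nM
compound 2 `COc1cc(-c2nn(-c3cccc(NC(=O)Nc4cccc(C(F)(F)F)c4)c3)cc2-c2ccncc2)ccc1Cl`, only a limit

For the measured compounds named here, compound 1 is the only member with a number. For compound 2 this assay gives > 50000 nM, which is a limit of the assay and not a number. Going by the values given here, the one measured step, an at least 2.2-fold higher number from compound 1 to compound 2 (0.36 log units; beyond the scatter), is the change from compound 1 to compound 2; it is at least modest and points toward weaker inhibition of growth, and its size is bounded only by the limit of > 50000 nM in this assay, at which 1 of the 2 values shown sits.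

Compound 3 `COc1cc(-c2nn(-c3cccc(NC(=O)c4ccccc4)c3)cc2-c2ccncc2)ccc1Cl` is not yet measured in this assay. It differs from compound 2 by phenyl in place of (3-(trifluoromethyl)phenyl)amino on a carbonyl carbon. No measured step covers this kind of change; the only step shown concerns a trifluoromethyl on the urea side and weakened growth inhibition. Compound 2 already sits at the limit, so compound 3 is expected to give no stronger inhibition and most likely a limit again, the step that the limit leaves unreadable from compound 2 to compound 3 being expected close to none. Compound 3 is therefore estimated at 60000 nM, within 20000 nM to 200000 nM.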

Compound 3, concentration for total growth inhibition: > 100000 nM
Compound 3 was reported as a limit; the forecaster's own chance of this, stated with the estimate: 75%; middle value at least 1.6-fold (0.22 log units) from the limit.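

In this assay compound 2 gives > 50000 nM, a limit and not a number. For the compounds shown here, compound 3 gives > 100000 nM, also a limit, so no step between the two can be read. The compounds shown leave open whether phenyl in place of (3-(trifluoromethyl)phenyl)amino on a carbonyl carbon changes growth inhibition at all.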